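Aryl swap on the triazole nitrogen, trimethoxyphenyl series

The source may hold more compounds than are shown below. What is called first, only, known or untested is meant among the compounds shown, and "the series" means these compounds.

Compound 1 `COc1cc(-c2ncnn2-c2cccc(N)c2)cc(OC)c1OC` carries the trimethoxyphenyl group on a ring carbon of the shared core and a 3-aminophenyl group on a ring nitrogen. In a functional assay on K562 cells (Homo sapiens) for antiproliferative activity, read by MTT assay, with a stated time of 72 h (on this read-out higher numbers stand for weaker inhibition and lower numbers for stronger inhibition), compound 1 gives > 10000 nM, which is a limit of the assay and not a number. Two further members share the core with the aryl groups the other way round: compound 2 `COc1cc(-n2ncnc2-c2ccc(F)cc2)cc(OC)c1OC` and compound 3 `COc1cc(-n2ncnc2-c2ccc(C)cc2)cc(OC)c1OC`. In this assay compound 2 gives > 10000 nM, a limit. In this assay compound 3 gives > 10000 nM, likewise a limit. For the measured compounds named here, the single one-place step, a step that the two limits leave unreadable from compound 2 to compound 3, is therefore not readable, and the whole picture so far is the limit of > 10000 nM in this assay, at which 3 of the 3 values shown sit.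

Compound 4 `COc1cc(-c2ncnn2-c2ccc(Cl)cc2Cl)cc(OC)c1OC` differs from compound 1 by 2,4-dichlorophenyl in place of 3-aminophenyl on an aromatic nitrogen. Going by the values given here, no measured step covers a change of this kind on the ring nitrogen, so there is nothing to read a direction from; the only guide is that every value so far sits at the limit. The expectation for compound 4 in this assay is accordingly that it will again be reported at or near the limit, with a step that the limit leaves unreadable from compound 1 to compound 4 being no step beyond the scatter. The estimate for compound 4 is 15000 nM, within 3000 nM to 60000 nM, with a substantial chance that only a limit is returned.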

Compound 4, half-maximal inhibitory concentration: > 10000 nM
Compound 4 was reported as a limit (the forecaster's own chance of this, stated with the estimate: 70%); the middle value is on the limit's open side.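

The step between compound 1 and compound 4 cannot be read: in this assay both stand only as limits and not as numbers. The compounds shown leave open which aryl groups on the shared core, if any, give a value that is a number, and the whole picture remains: the limit of > 10000 nM in this assay, at which 4 of the 4 values shown sit.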